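This account rests on a few compounds, and the source may have more. Where it says the series, first, only, none or still open, it means among the compounds named here.

Working notes on the series. Compound 1 `N/C(=N\NC(=S)N1CCCCCC1)c1ccccn1` and compound 2 `N/C(=N\NC(=S)N1CCOCC1)c1ccccn1` differ in their cores, and that difference between the two cores is not broken down here. In a functional assay on A-375 cells (Homo sapiens) for cytotoxicity, read by MTT assay, with a stated time of 72 h, tested at 100 uM (a higher number here means more inhibition of growth at the concentration tested, a lower number less inhibition of growth), compound 1 gives 89%, whereas compound 2 gives 14%. Compound 3 `Cc1ccnc(/C(N)=N/NC(=S)N2CCOCC2)c1` arises from compound 2 by one change, (methyl in place of hydrogen on an aromatic carbon), and in this assay compound 3 gives 90.6%. The step that this change made is a number 76.6 percentage points higher from compound 2 to compound 3 (beyond the scatter). The values of compound 1 and compound 3 lie within the scatter of each other.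

Compound 4 `Cc1ccnc(/C(N)=N/NC(=S)N2CCCCCC2)c1` is not yet measured. It arises from compound 1 by the same change, (methyl in place of hydrogen on an aromatic carbon), on the core of compound 1. Within the data shown here, a step as large as the one from compound 2 to compound 3 is not expected here, because compound 1 already gives 89% and the read-out cannot rise past complete inhibition of growth. Compound 4 is therefore expected to give 92% in this assay. The expected range for compound 4 runs from 82% to 99%. The expected step of a number 3 percentage points higher from compound 1 to compound 4 (within the scatter) would stay within the scatter.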

Compound 4, percent growth inhibition at one concentration: 77%
Compound 4: the middle estimate sits 15 percentage points above what was measured; measured number below the stated range.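

In this assay, methyl in place of hydrogen on an aromatic carbon, opposite the ring nitrogen, gives a number 12 percentage points lower from compound 1 to compound 4 (beyond the scatter). The change therefore does not carry over from one core to the other with a common direction or size in this series: the same change on two cores in this assay, a number 76.6 percentage points higher (beyond the scatter) from compound 2 to compound 3 and a number 12 percentage points lower (beyond the scatter) from compound 1 to compound 4, 88.6 percentage points apart, beyond the scatter of two such steps. What these two pairs do not show is what sets them apart: the two steps start from different levels, with compound 2 at 14% and compound 1 at 89%, and neither the core itself nor the starting level can be singled out as the deciding factor.

The compounds shown carry only hydrogen or methyl at this place, and it remains open how an amine, a methoxy group or a longer chain such as ethyl would behave there on either core. Also open, on these data alone, is which of the two steps, if either, a third core would follow.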